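A few compounds are considered here, and "the series" means these few. Any claim that something is new, unique, unknown or untested is made for them only; others in the source may bear on it.

Working notes on the series built on the shared core of compound 1 `COc1cccc(N2C(=O)COc3ccc(-c4cnc5ccccc5c4)cc32)c1`, read in a functional assay on HCT-116 cells (Homo sapiens) for antiproliferative activity, read by MTT assay, with a stated time of 72 h; a lower number here means a stronger inhibitor, a higher number a weaker inhibitor. Among the compounds with values here, compound 1 gives 8240 nM, the only reading so far that is a number. Compound 2 `COc1ccc(N2C(=O)COc3ccc(-c4cnc5ccccc5c4)cc32)cc1` gives > 40000 nM, which is a limit of the assay. Compound 3 `O=C1COc2ccc(-c3cnc4ccccc4c3)cc2N1c1ccc(F)cc1` gives > 40000 nM, again a limit and not a number. Compound 3 therefore stands at the limit of > 40000 nM in this assay, at which 2 of the 3 values shown sit.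

Compound 4 `O=C1COc2ccc(-c3cnc4ccccc4c3)cc2N1c1ccc(Cl)cc1` is the next analogue, with this difference: chloro in place of fluoro on an aromatic carbon. In short, chloro replaces fluoro on an aromatic carbon, para to a large group, so 4-fluorophenyl becomes 4-chlorophenyl.

Two measured steps change the same aryl group on the ring nitrogen. One is an at least 4.8-fold higher number from compound 1 to compound 2 (0.68 log units; beyond the scatter), and the other is an at least 4.8-fold higher number from compound 1 to compound 3 (0.68 log units; beyond the scatter). Both replace 3-methoxyphenyl and both end at the limit. The closest comparison, a swap at the same aromatic carbon, gives only a step that the two limits leave unreadable from compound 2 to compound 3, so it offers no size to carry over. No step beyond the scatter is therefore expected in this assay, and another reading at the limit is the likeliest outcome. The expected change is a number no higher from compound 3 to compound 4 (the limit leaves the size open). The estimate for compound 4 is 40000 nM, with an expected range of 15000 nM to 80000 nM.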

Compound 4, half-maximal inhibitory concentration: 36100 nM
Compound 4: the middle estimate sits 1.1-fold (0.04 log units) above what was measured; measured number inside the range.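

In this assay, within the data shown here, the 4-chlorophenyl group gives the first step on this aryl group that ends on a number and not at a limit, and that step is beyond the scatter: a 4.4-fold higher number from compound 1 to compound 4 (0.64 log units; beyond the scatter). Chloro in place of fluoro and chloro in place of methoxy on this aromatic carbon give only floors within the scatter, an at least 1.1-fold lower number from compound 3 to compound 4 (0.04 log units; that floor lies within the scatter) and an at least 1.1-fold lower number from compound 2 to compound 4 (0.04 log units; that floor lies within the scatter), so neither change can be called a gain and the true size of both steps cannot be read. Compound 2 and compound 3 remain limits and not numbers, so this aromatic carbon still offers no full scale for comparing chloro, fluoro and methoxy: the limit of > 40000 nM in this assay, at which 2 of the 4 values shown sit.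

On these data alone, what an amine or a carboxylic acid in place of chloro on this aromatic carbon would read stays open. Also open, as far as these compounds go, is whether any other aryl group on the ring nitrogen can read lower than compound 1, which gives 8240 nM.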